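The compounds below may be only part of what the source reports. "The series", "measured", "known", "first", "only" and "open" are said of these compounds alone.

Of the compounds shown here, three built on one shared core have been tested in a functional assay on HL-60 cells (Homo sapiens) for cytotoxicity, read by MTT assay, with a stated time of 24 h; a lower number here means a stronger inhibitor, a higher number a weaker inhibitor. Compound 1 `COc1ccccc1N1CCN(CCCCCOc2c(Br)cc(Br)cc2Oc2ccc(Br)cc2Br)CC1` gives 32.2 ug/mL. Compound 3 `CC(C)(C)OC(=O)N1CCN(CCCCCOc2c(Br)cc(Br)cc2Oc2ccc(Br)cc2Br)CC1` gives 32.1 ug/mL, and the step of a 1.0-fold lower number from compound 1 to compound 3 (0.00 log units; within the scatter) lies within the scatter. Compound 2 `C#CCOc1c(Br)cc(Br)cc1Oc1ccc(Br)cc1Br` gives 29.7 ug/mL, the lowest of the three numbers shown, though its gaps to compound 3 and to compound 1 both lie within the scatter, so no order among the three can be read from these values.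

Compound 4 `BrCCOc1c(Br)cc(Br)cc1Oc1ccc(Br)cc1Br` has not yet been measured. It differs from compound 2 in one place: bromomethyl in place of ethynyl on a saturated chain carbon bound to an oxygen on an aromatic ring. Going by the values given here, no measured step touches this place; the only measured step, a 1.0-fold lower number from compound 1 to compound 3 (0.00 log units; within the scatter), concerns an amine nitrogen in a ring elsewhere on the molecule and stays within the scatter. The three measured values sit close together, and nothing shown points to a shift. Compound 4 is therefore expected to give 30 ug/mL, within a range from 15 ug/mL to 60 ug/mL, which amounts to an estimated step of a 1.0-fold higher number from compound 2 to compound 4 (0.00 log units; within the scatter) that stays within the scatter.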

Compound 4, half-maximal inhibitory concentration: 26.2 ug/mL
The estimate for compound 4 lay 1.1-fold (0.06 log units) above the measured number, within the range that was stated.
By their numbers in this assay, from the lowest: compounds 4, 2, 3 and 1 (each within the scatter of the next).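

Going by these compounds alone, compounds 2 and 4 give the first measured change at this position, on a saturated chain carbon bound to an oxygen on an aromatic ring. In this assay, replacing ethynyl with bromomethyl, which turns propargyloxy into 2-bromoethoxy, gives a 1.1-fold lower number from compound 2 to compound 4 (0.05 log units; within the scatter), so the two compounds cannot be told apart and the triple bond is not needed for a value of this size. Nothing measured here offers an explanation for this result.

From the compounds shown here alone, it remains open whether any group at this position can move the value beyond the scatter. A carboxylic acid or a hydroxyl group at the end of this short chain would show whether the assay responds to a change here at all.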